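This account rests on a few compounds, and the source may have more. Where it says the series, first, only, none or still open, it means among the compounds named here.

Measured compounds:
compound 1, `COc1cc(/C=C/C(C)=O)ccc1OCc1cn(-c2ccccc2CO)nn1`, gives 50300 nM in a functional assay on PC-3 cells (Homo sapiens) for antiproliferative activity, read by MTT assay, with a stated time of 48 h; a higher number here means a weaker inhibitor, a lower number a stronger inhibitor.
compound 2, `COc1cc(/C=C/C(C)=O)ccc1OCc1cn(-c2ccc(C(F)(F)F)c(C(F)(F)F)c2)nn1`, gives 67200 nM in this assay.

Compound 1 has the lower of these two numbers, but its gap to compound 2 lies within the usual scatter of repeated measurements, so the two compounds cannot be told apart on these data. Both sit in the weak range of this assay.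

Compound 3, `COc1cc(/C=C/C(C)=O)ccc1OCc1cn(-c2cc(F)cc(Br)c2)nn1`, has not yet been measured. It keeps the shared core of compound 1 and changes only one place: 3-bromo-5-fluorophenyl in place of 2-(hydroxymethyl)phenyl on an aromatic nitrogen. Among the measured compounds shown here, since no measured pair shows what this kind of change does, the expectation rests on the two numbers alone, which show that the group on that aromatic nitrogen made little difference between compound 1 and compound 2. Compound 3 is therefore expected to give about 55000 nM in this assay, with a likely range from 25000 nM to 120000 nM. The step from compound 1 that this estimate means, a 1.1-fold higher number from compound 1 to compound 3 (0.04 log units; within the scatter), is expected to be no larger than the scatter, in no clear direction.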

Compound 3, half-maximal inhibitory concentration: 56900 nM
Beside the measured number, compound 3's estimate is 1.0-fold (0.01 log units) below it, and the stated range covers the measured number.
By their numbers in this assay, from the lowest: compounds 1, 3 and 2 (each within the scatter of the next).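

Replacing 2-(hydroxymethyl)phenyl with 3-bromo-5-fluorophenyl on the aromatic nitrogen gives a 1.1-fold higher number from compound 1 to compound 3 (0.05 log units; within the scatter) in this assay. The leaving group has 1 hydrogen-bond donor and 1 hydrogen-bond acceptor, while the entering group has 0 of each, so at this position, losing both counts and bringing in fluorine and bromine leaves no difference that can be told from the scatter. Nothing measured here explains this result.

The compounds shown leave open whether an aminomethyl group or a carboxylic acid on this phenyl ring, or a cyclohexyl ring in its place, would separate from these numbers. They also do not show whether any group on this nitrogen can shift the number beyond the scatter in this assay.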